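The compounds below may be only part of what the source reports. "The series", "measured", "known", "first", "only" and "open" are said of these compounds alone.

Measured so far in an ADME assay on 184B5 cells (Homo sapiens) for cytotoxicity, read by MTT assay, with a stated time of 72 h; a higher number here means a weaker inhibitor of growth, a lower number a stronger inhibitor of growth:
compound 1, `CCCOC(=O)Nc1ccc([Se]C#N)cc1`, 3700 nM
compound 2, `CC(C)COC(=O)Nc1ccc([Se]C#N)cc1`, 5800 nM

Among the measured compounds shown here, compound 2 gives the highest of the two numbers, yet its only neighbour is compound 1, and the step of a 1.6-fold higher number from compound 1 to compound 2 (0.20 log units; within the scatter) sits within the scatter, so the two compounds cannot be ranked against each other on this evidence. Compound 3, `C=CCOC(=O)Nc1ccc([Se]C#N)cc1`, is not yet measured. It differs from compound 2 in one place: vinyl in place of isopropyl on a saturated chain carbon bound to an oxygen next to a carbonyl group. For the measured compounds named here, only one measured step is available for comparison, the branch added along the same chain from compound 1 to compound 2, and that step, a 1.6-fold higher number from compound 1 to compound 2 (0.20 log units; within the scatter), did not rise above the scatter. The move to compound 3 trims the chain and introduces a double bond rather than adding a branch, so it is a different kind of change, and nothing measured here bears on it directly. Going by the values given here, with no step of size on record for this chain, the expectation for compound 3 is a number close to compound 2, with the step of a 1.3-fold lower number from compound 2 to compound 3 (0.11 log units; within the scatter) expected to stay inside the scatter. Compound 3 is therefore estimated at 4500 nM, within 1800 nM to 11000 nM.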

Compound 3, concentration for 50% growth inhibition: 5000 nM
The estimate for compound 3 lay 1.1-fold (0.05 log units) below the measured number; the range from low to high includes it.
By their numbers in this assay, from the lowest: compounds 1, 3 and 2 (each within the scatter of the next).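

In this assay, vinyl in place of isopropyl on a saturated chain carbon bound to an oxygen next to a carbonyl group gives a 1.2-fold lower number from compound 2 to compound 3 (0.06 log units; within the scatter) and vinyl in place of ethyl at the same place gives a 1.4-fold higher number from compound 1 to compound 3 (0.13 log units; within the scatter) so both changes stay inside the scatter. Among the compounds shown here, until now the only step on record was a branch added along this chain; these two steps add that isobutoxy to allyloxy, which brings in a double bond outside aromatic rings, also yields no readable change, and the three compounds therefore cannot be ranked against one another in this assay on this evidence. No supporting measurement is available to explain why these changes leave the number within the scatter.

The compounds shown leave open whether any group at this place can move the number beyond the scatter, for example a longer chain, a benzyl group or an amine carried on the same chain carbon. They also leave open whether replacing the carbamate oxygen, or changing the shared core, would produce a step larger than any seen here.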